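The source may report more compounds than this note shows. Statements on the series, on what has been measured and on what is new or still open speak of the compounds shown alone.

In an assay on isolated protein for agonist activity at Bile acid receptor (Homo sapiens), read by AlphaScreen, with a stated time of 30 min (on this read-out higher numbers stand for an effect only at larger amounts of compound and lower numbers for an effect already at smaller amounts), the series is read on a shared core that appears in each of the compounds described here. Compound 1 `COC(=O)c1ccc(-c2ccc([C@H]3S[C@@H](C)C(=O)Nc4c3c(C)nn4-c3ccccc3C)cc2)cc1` gives "not active" (no number reported) in this assay. Among the compounds with values here, compound 2 `Cc1cccc(-n2nc(C)c3c2NC(=O)[C@H](C)S[C@@H]3c2ccc(Oc3ccccc3)cc2)c1` gives 2400 nM in this assay, and it is the only member of the set for which a number is reported at all. Compound 3 `Cc1ccccc1-n1nc(C)c2c1NC(=O)[C@H](C)S[C@@H]2c1ccc(Oc2cccc(C(=O)O)c2)cc1` gives "not active" (no number reported) in this assay, so compound 3 stands, together with compound 1, among the entries without a single number, while compound 2 alone shows a measurable effect.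

Compound 4 `COc1ccccc1-c1ccc([C@H]2S[C@@H](C)C(=O)Nc3c2c(C)nn3-c2ccccc2C)cc1` has not yet been measured in this assay. It differs from compound 3 in one place: 2-methoxyphenyl in place of 3-carboxyphenoxy on an aromatic carbon. Within the data shown here, no step between measured compounds has been reported for this change, so its size in this assay can only be expected, not read from the data. Because compound 3 gives "not active" (no number reported) and compound 1 gives "not active" (no number reported) in this assay, there is a fair chance that compound 4 also returns no number; on the other hand compound 2 gives 2400 nM in this assay, so a weak effect is not excluded. Compound 4 is therefore expected to give about 3500 nM in this assay, with a likely range from 800 nM to 15000 nM.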

Compound 4, half-maximal effective concentration: 1100 nM
Compound 4: the middle estimate sits 3.2-fold (0.50 log units) above what was measured, within the range that was stated.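

In this assay compound 4 gives 1100 nM while compound 3 gives "not active" (no number reported), so no step can be read between compound 3 and compound 4. The compounds shown leave open how large the change from 3-carboxyphenoxy to 2-methoxyphenyl is on this read-out. Nothing given here offers an explanation for the value of compound 4.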